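The compounds below may be only part of what the source reports. "The series", "measured", "known", "first", "only" and "open" are said of these compounds alone.

Measured compounds and their values:

Compound 1, `Cc1cccc(Oc2ccc(C#N)cc2S(=O)(=O)NC(=O)NC(C)(C)C)c1`, in a functional assay on HEK293 cells for antagonist activity at thromboxane A2 receptor (Homo sapiens), read by fluorescence and calcium flux (on this read-out lower numbers stand for stronger inhibition and higher numbers for weaker inhibition), gives 690 nM.
Compound 2, `CCCCCNC(=O)NS(=O)(=O)c1cc(C#N)ccc1Oc1cccc(C)c1`, in this assay gives 680 nM.
Compound 3, `CC(C)(C)NC(=O)NS(=O)(=O)c1cc(C#N)ccc1Oc1ccc(F)cc1`, in this assay gives 3890 nM.

Two single-point changes connect these three. The change pentyl in place of tert-butyl on an amide-type nitrogen produces a 1.0-fold lower number from compound 1 to compound 2 (0.01 log units; within the scatter), so compounds 1 and 2 cannot be told apart in this assay. The change 4-fluorophenyl in place of 3-methylphenyl on an oxygen on an aromatic ring produces a 5.6-fold higher number from compound 1 to compound 3 (0.75 log units; beyond the scatter); compound 3 therefore stands apart from both compound 1 and compound 2, and its number is the weakest of the three.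

Compound 4, `CCCCCNC(=O)NS(=O)(=O)c1cc(C#N)ccc1Oc1ccc(F)cc1`, has not yet been measured. Among the compounds with values here, it differs from compound 3 by pentyl in place of tert-butyl on an amide-type nitrogen, which is the same change as the one from compound 1 to compound 2; the two "place" descriptions read identically, so it is the same change. The cores of compound 3 and compound 4 differ from those of compound 1 and compound 2 by 4-fluorophenyl in place of 3-methylphenyl on an oxygen on an aromatic ring. This change occurs twice among the four compounds, once measured.

For compound 4 the step of a 1.0-fold higher number from compound 3 to compound 4 (0.00 log units; within the scatter) is expected to resemble a 1.0-fold lower number from compound 1 to compound 2 (0.01 log units; within the scatter), resting on that single measured pair, compound 1 and compound 2, which gives no sign that the tert-butyl to pentyl exchange matters here. From the compounds shown here alone, whether that holds on the 4-fluorophenoxy core is untested, so the range is kept wide. Compound 4 is estimated at 3900 nM, with a likely span from 1500 nM to 10000 nM.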

Compound 4, half-maximal inhibitory concentration: 9530 nM
Compound 4: middle estimate off by 2.4-fold (0.39 log units), on the low side; measured number inside the range.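

In this assay, pentyl in place of tert-butyl on an amide-type nitrogen gives a 2.4-fold higher number from compound 3 to compound 4 (0.39 log units; beyond the scatter), and its size on the two cores does not differ beyond the scatter: the same change on two cores in this assay, a 1.0-fold lower number (0.01 log units; within the scatter) from compound 1 to compound 2 and a 2.4-fold higher number (0.39 log units; beyond the scatter) from compound 3 to compound 4, 2.5-fold (0.40 log units) apart, within the scatter of two such steps. The other change, 4-fluorophenyl in place of 3-methylphenyl on an oxygen on an aromatic ring, gives a 14-fold higher number from compound 2 to compound 4 (1.15 log units; beyond the scatter) and likewise reads the same on both cores within the scatter: the same change on two cores in this assay, a 5.6-fold higher number (0.75 log units; beyond the scatter) from compound 1 to compound 3 and a 14-fold higher number (1.15 log units; beyond the scatter) from compound 2 to compound 4, 2.5-fold (0.40 log units) apart, within the scatter of two such steps. These notes therefore support carrying each change between these two cores only; with a single pair per core, they do not show that either change transfers to a further core, nor do they settle whether the pentyl step truly differs between the two cores or is the same on both.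

Open on the amide-type nitrogen is the response to groups other than these two, such as an ethyl group, a longer chain such as octyl, or a chain ending in an amine. Open on the oxygen is how a plain phenyl or a phenyl carrying a carboxylic acid would read, and whether either would follow the same steps on both tert-butyl and pentyl compounds.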